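The source may hold more compounds than are shown below. What is called first, only, known or untested is meant among the compounds shown, and "the series" means these compounds.

Compound 1 `COc1ccc(Cn2cnc3c(-c4cc5ccccc5o4)nc(Cl)nc32)cc1` is the reference point for this step. In an ADME assay on Vero cells (Chlorocebus sabaeus) for cytotoxicity, read by MTT assay, with a stated time of 72 h (on this read-out higher numbers stand for weaker inhibition and lower numbers for stronger inhibition), compound 1 gives > 40 ug/mL, which is a limit of the assay and not a number. Compound 3 `COc1ccc(Cn2cnc3c(/C=C4\OCc5ccccc54)nc(Cl)nc32)cc1` likewise returns only a limit in this assay, > 40 ug/mL. For the measured compounds named here, the one numerical value comes from compound 2 `C(=C1\OCc2ccccc21)\c1ncnc2c1ncn2Cc1ccccc1`, which in this assay gives 17 ug/mL. Compound 1 therefore stands at the limit of > 40 ug/mL in this assay, at which 2 of the 3 values shown sit, so its position can be stated only as that bound; it cannot be ranked against compound 3, and only compound 2 is known to sit inside the measured range.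

Compound 4 `COc1ccc(Cn2cnc3c(/C=C/c4ccccc4)nc(Cl)nc32)cc1` differs from compound 1 by 2-phenylethenyl in place of 1-benzofuran-2-yl on an aromatic carbon, with the chloro group and the rest of the shared core kept. Going by the values given here, no measured pair in the set isolates such a change, so there is no step to lean on. The expectation is that this assay shows no shift beyond the scatter, with the step from compound 1 to compound 4 estimated as a number no higher from compound 1 to compound 4 (the limit leaves the size open), and that compound 4 most likely again reaches only the limit. Compound 4 is accordingly estimated at 40 ug/mL, within 15 ug/mL to 80 ug/mL, pending the measurement.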

Compound 4, half-maximal inhibitory concentration: > 40 ug/mL
Compound 4 gave a limit, no number; the forecaster's own chance of this, stated with the estimate: 65%; the middle value lies on the limit itself.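

In this assay, compound 1 and compound 4 each return only a limit of the assay, not a number, so no step can be read between them: the limit of > 40 ug/mL in this assay, at which 3 of the 4 values shown sit. The compounds shown leave open whether 2-phenylethenyl in place of 1-benzofuran-2-yl changes the read-out at all.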